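Swapping Chloro for Methoxy on the Aromatic Ring

A few compounds are considered here, and "the series" means these few. Any claim that something is new, unique, unknown or untested is made for them only; others in the source may bear on it.

Compound 3 `COc1cc(-n2cnc3ccc(-c4ccc(Cl)cc4)cc32)cc(OC)c1OC` carries a 4-chlorophenyl group on the shared core, and in a functional assay on SGC-7901 cells (Homo sapiens) for antiproliferative activity, read by MTT assay, with a stated time of 72 h (on this read-out higher numbers stand for weaker inhibition and lower numbers for stronger inhibition), compound 3 gives 1270 nM. Among the numbers shown, compound 3 sits highest. Where compound 3 carries chloro, compound 1 `COc1cc(-n2cnc3ccc(-c4ccc([N+](=O)[O-])cc4)cc32)cc(OC)c1OC` carries a nitro group and gives 79 nM in this assay. The step of a 16-fold higher number from compound 1 to compound 3 (1.21 log units; beyond the scatter). Compound 2 `COc1cc(-c2ccc3ncn(-c4cc(OC)c(OC)c(OC)c4)c3c2)cc(OC)c1OC` reaches only a limit of this assay, > 10000 nM, and not a number. Compound 4 `COc1ccc(-c2ccc3ncn(-c4cc(OC)c(OC)c(OC)c4)c3c2)cc1` differs from compound 3 in one place: methoxy in place of chloro on an aromatic carbon. Among the measured compounds shown here, no measured step covers methoxy in place of chloro, so the only guide is the size of the one measured step, in which exchanging the group at this same spot, nitro for chloro, moved the number by a large amount. Nothing shown fixes the direction for methoxy, though the one compound bearing methoxy groups on both aromatic rings, compound 2, returned only a limit. Compound 4 is therefore expected to land near compound 3 or somewhat higher, with the estimated step of a 2.4-fold higher number from compound 3 to compound 4 (0.37 log units; beyond the scatter). The estimate for compound 4 is 3000 nM, spanning from 800 nM to 12000 nM.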

Compound 4, half-maximal inhibitory concentration: 82 nM
For compound 4 the middle estimate is 37-fold (1.56 log units) above the measured one, outside the stated range (below it).
By their numbers in this assay, from the lowest: compounds 1 and 4 (each within the scatter of the next); then compound 3. At a limit, above all of these: compound 2.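

In this assay, methoxy in place of chloro on this aromatic carbon gives a 15-fold lower number from compound 3 to compound 4 (1.19 log units; beyond the scatter) and so brings the number back down. The earlier compounds shown here showed only that chloro gives a higher number than nitro at this spot, whereas this step shows that the loss is not a general one for groups other than nitro. Methoxy and nitro also sit level with each other, at a 1.0-fold higher number from compound 1 to compound 4 (0.02 log units; within the scatter) and therefore within the usual scatter, which leaves chloro as the one of the three groups that stands apart, so this carbon, para to a large group, responds strongly to some exchanges and hardly at all to others.

The data shown offer no measured reason why chloro parts from the other two groups here.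

Going by these compounds, it also stays open whether an amine, a carboxylic acid or a simple methyl group on this carbon would give a number close to those of methoxy and nitro or one closer to that of chloro.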